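The source may report more compounds than this note shows. Statements on the series, on what has been measured and on what is new or still open speak of the compounds shown alone.

Measured in an in vitro functional assay on HEK285-7 cells for antagonist activity at prostaglandin D2 receptor 2 (Homo sapiens), read by BRET and beta-arrestin recruitment; on this read-out higher numbers stand for larger maximal responses and lower numbers for smaller maximal responses:
compound 1 `O=C(O)Cc1sc(C(c2ccc(F)cc2)c2ccc(F)cc2)nc1-c1ccnc(N2CCCC2)c1`, 80%
compound 2 `O=C(O)Cc1sc(Cc2ccccc2)nc1-c1ccc(Cl)cc1`, 50%
compound 3 `O=C(O)Cc1sc(C(c2ccccc2)c2ccccc2)nc1-c1cccc(F)c1`, 80%

Compound 1 and compound 3 give the same reading; their gap lies within the scatter, so no order is set between them, and together they hold the higher end of the three. Compound 2 lies clearly lower than compound 1, beyond the scatter.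

Compound 4 `CN(C)c1cc(-c2nc(C(c3ccc(F)cc3)c3ccc(F)cc3)sc2CC(=O)O)ccn1` differs from compound 1 in one place: dimethylamino in place of pyrrolidin-1-yl on an aromatic carbon. For the measured compounds named here, no measured pair in this set shows this change, so nothing puts a size on it. A step without change beyond the scatter is expected here, with a slight drop as the more likely side; the expected step is a number 5 percentage points lower from compound 1 to compound 4 (within the scatter). For compound 4 the estimate in this assay is 75%, within 55% to 95%.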

Compound 4, largest response reached (reported as efficacy), in percent of the reference or control that the assay uses: 80%
Beside the measured number, compound 4's estimate is 5 percentage points below it; the range from low to high includes it.
By their numbers in this assay, from the lowest: compound 2; then compounds 1, 3 and 4 (each within the scatter of the next).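

Exchanging pyrrolidin-1-yl for dimethylamino in this assay, on the aromatic carbon next to the ring nitrogen, gives no change at the digits printed from compound 1 to compound 4 (within the scatter). In this pair, the five-membered non-aromatic ring is therefore not required to keep the maximal response, and the open group with fewer heavy atoms serves as well. No supporting data bear on why the reading holds. The compounds shown leave open whether a primary amine, a methoxy group or a hydrogen at this place would hold the response. Larger rings such as piperidin-1-yl and morpholin-4-yl also remain open.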